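Methoxy to hydroxy: compound 2 to compound 3

The source may report more compounds than this note shows. Statements on the series, on what has been measured and on what is new or still open speak of the compounds shown alone.

Measured in a functional assay on Huh-7 cells (Homo sapiens) for inhibition, read by MTT assay, with a stated time of 48 h; a lower number here means a stronger inhibitor, a higher number a weaker inhibitor:
- compound 1 `O=C(/C=C/c1coc2cc(O)ccc2c1=O)NCc1ccccc1`: 4690 nM
- compound 2 `COc1ccc2c(=O)c(/C=C/C(=O)NCc3ccc(C)cc3)coc2c1`: 14300 nM

Compound 2 holds the higher of the two numbers, and its gap to compound 1 lies beyond the scatter. Compound 3 `Cc1ccc(CNC(=O)/C=C/c2coc3cc(O)ccc3c2=O)cc1` differs from compound 2 in one place, with hydrogen in place of methyl on an oxygen on an aromatic ring, that is, methoxy to hydroxy. For the measured compounds named here, no measured pair isolates this change. The expectation rests on compound 1, which carries the hydroxy and gives 4690 nM. A modest move towards a lower number in this assay is expected, a 2.2-fold lower number from compound 2 to compound 3 (0.34 log units; beyond the scatter). The estimated value for compound 3 is 6500 nM, with an expected range of 2500 nM to 16000 nM.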

Compound 3, half-maximal inhibitory concentration: > 100000 nM
Compound 3 was reported as a limit (the forecaster's own chance of this, stated with the estimate: 3%); middle value at least 15-fold (1.18 log units) from the limit.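

In this assay, methoxy to hydroxy on this oxygen gives an at least 6.9-fold higher number from compound 2 to compound 3 (0.84 log units; beyond the scatter), so the hydroxy alone does not secure a lower number. With the hydroxy held, methyl in place of hydrogen on an aromatic carbon gives an at least 21-fold higher number from compound 1 to compound 3 (1.32 log units; beyond the scatter), so the outcome of the hydroxy depends on what else the compound carries. Compound 3 is reported only as a limit, not as a number: the limit of > 100000 nM in this assay, at which 1 of the 3 values shown sits.

As far as these compounds go, how far compound 3 lies beyond that limit stays open. Also open, from the compounds shown here alone, is whether a chloro or an ethyl on that aromatic carbon, or an ethoxy on the oxygen, would behave like the methyl or the methoxy.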